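Swapping the amide aryl group for isopropyl: clearance outlook

The compounds below may be only part of what the source reports. "The series", "measured", "known", "first", "only" and "open" are said of these compounds alone.

Measured compounds:
Compound 1 `CN1C[C@H](C(=O)Nc2ccc(C#N)cc2)[C@@H](c2ccc(/C=C/C(=O)Nc3ccccc3N)cc2)C1` gives 35 mL/min/kg in an in vitro ADME assay on microsomes from liver (Mus musculus) for pharmacokinetics, read by LC-MS, with a stated time of 10 min, tested at 1 uM; a higher number here means faster removal of the compound, a lower number slower removal.
Compound 2 `Cc1cccc(NC(=O)[C@H]2CN(C)C[C@@H]2c2ccc(/C=C/C(=O)Nc3ccccc3N)cc2)c1` gives 74 mL/min/kg in this assay.
Compound 3 `CN1C[C@H](C(=O)Nc2ccc(Cl)c(Cl)c2)[C@@H](c2ccc(/C=C/C(=O)Nc3ccccc3N)cc2)C1` gives 36 mL/min/kg in this assay.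

Three compounds share one core and differ only in the group on the amide-type nitrogen. Compound 3, with its 3,4-dichlorophenyl, sits close to compound 1, the two being indistinguishable given the usual scatter, while compound 2 stands clearly higher, as shown by a 2.1-fold lower number from compound 2 to compound 3 (0.31 log units; beyond the scatter) and a 2.1-fold higher number from compound 1 to compound 2 (0.33 log units; beyond the scatter). The step of a 1.0-fold higher number from compound 1 to compound 3 (0.01 log units; within the scatter) shows that exchanging one aromatic group for another need not move the number at all.

Compound 4 `CC(C)NC(=O)[C@H]1CN(C)C[C@@H]1c1ccc(/C=C/C(=O)Nc2ccccc2N)cc1` is not yet measured. Its change from compound 3 is isopropyl in place of 3,4-dichlorophenyl on an amide-type nitrogen. Within the data shown here, no measured step bears directly on this change: every measured step swaps one six-membered aromatic ring for another, and none brings in a group without a ring. The measured steps span only a modest range, so a step of similar size in either direction, or none beyond the scatter, is all that can be expected.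

Compound 4 is therefore estimated at 45 mL/min/kg, with a range from 20 mL/min/kg to 100 mL/min/kg, which means an expected step of a 1.3-fold higher number from compound 3 to compound 4 (0.10 log units; within the scatter).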

Compound 4, clearance: 12 mL/min/kg
Beside the measured number, compound 4's estimate is 3.8-fold (0.57 log units) above it; the whole stated range lies above it.
By their numbers in this assay, from the lowest: compound 4; then compounds 1 and 3 (each within the scatter of the next); then compound 2.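

In this assay, among these compounds, the change to isopropyl, the first group here without a ring, lowers the number whichever aromatic group it replaces: a 3.0-fold lower number from compound 3 to compound 4 (0.48 log units; beyond the scatter) and a 2.9-fold lower number from compound 1 to compound 4 (0.46 log units; beyond the scatter) and a 6.2-fold lower number from compound 2 to compound 4 (0.79 log units; beyond the scatter) are all beyond the scatter. The earlier swaps of one aromatic group for another showed only that this position could leave the number unchanged or, with 3-methylphenyl, raise it, whereas compound 4 shows that a group on the amide-type nitrogen can bring the number below those of all three aromatic compounds. Within these four compounds, the lowest number goes with the only group lacking a ring, and no compound goes against that.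

Isopropyl also has fewer heavy atoms than 3,4-dichlorophenyl, so the loss of the ring and the lower atom count are tied together here, and a cyclohexyl ring or a longer chain such as n-butyl would be needed to pull them apart. Nothing among the data shown explains why the number falls.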